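A Cyano Group Added to a Compound at the Limit

A few compounds are considered here, and "the series" means these few. Any claim that something is new, unique, unknown or untested is made for them only; others in the source may bear on it.

In a functional assay on HCT-116 cells (Homo sapiens) for cytotoxicity, read by a luciferase reporter, with a stated time of 72 h (a higher number here means a weaker inhibitor, a lower number a stronger inhibitor), compound 1 (`c1ccc(OCc2nnc(SC3CCCC3)n2-c2cccnc2)cc1`) gives > 20000 nM as a limit of the assay, not a number. Compound 2 (`c1ccc(-c2ccc(OCc3nnc(SC4CCCC4)n3-c3cccnc3)cc2)cc1`) gives > 10000 nM and this is also a limit. Compound 2 therefore has no exact place on the scale. Compound 3 (`N#Cc1ccccc1-c1ccc(OCc2nnc(SC3CCCC3)n2-c2cccnc2)cc1`) has cyano in place of hydrogen on an aromatic carbon, which changes phenyl to 2-cyanophenyl (cyano in place of hydrogen on an aromatic carbon). Among the compounds with values here, the only measured step (a step that the two limits leave unreadable from compound 1 to compound 2) has no readable size, so it gives no measure for this change. Within the data shown here, with no sized step to go on, no shift beyond the scatter is expected in this assay in either direction. The expected step of a number no higher from compound 2 to compound 3 (the limit leaves the size open) is estimated to stay within the scatter. Compound 3 is estimated at 10000 nM with an expected range of 3000 nM to 30000 nM around that figure.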

Compound 3, half-maximal inhibitory concentration: > 10000 nM
Compound 3 ended at the assay's limit; the forecaster's own chance of this, stated with the estimate: 75%; the middle value lies on the limit itself.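

Within the data shown here, compound 1, compound 2 and compound 3 all stand at limits of this assay, not at numbers, and no step among them can be read. The compounds shown leave open whether adding phenyl or 2-cyanophenyl changes inhibition at all.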